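The compounds below may be only part of what the source reports. "The series", "measured", "known", "first", "only" and "open" are said of these compounds alone.

Compound 1, `O=C(/C=C/c1ccc2c(c1)B(O)OC2)c1ccccc1`, was tested in an ADME assay on L929 cells (Mus musculus) for cytotoxicity, read by resazurin assay, with a stated time of 72 h; on this read-out higher numbers stand for weaker inhibition and lower numbers for stronger inhibition. In this assay compound 1 gives > 10 ug/mL, which is a limit of the assay and not a measured number. Compound 2, `COc1ccccc1C(=O)/C=C/c1ccc2c(c1)B(O)OC2`, carries a methoxy in place of hydrogen on an aromatic carbon; in this assay compound 2 gives 6.35 ug/mL. The step is an at least 1.5-fold lower number from compound 1 to compound 2 (0.19 log units; that floor lies within the scatter), and its true size cannot be fixed because compound 1 sits at the limit of > 10 ug/mL in this assay, at which 1 of the 2 values shown sits. Compound 3, `Cc1ccc(C(=O)/C=C/c2ccc3c(c2)B(O)OC3)cc1`, has not yet been measured; relative to compound 1 it shows (methyl in place of hydrogen on an aromatic carbon). Going by the values given here, the only measured step that bears on this change is the one from compound 1 to compound 2, and it sets no more than a floor that lies within the usual scatter. A methyl is a smaller addition than a methoxy, so no step beyond the scatter is expected, with a fair chance that the assay again reports only a limit. Compound 3 is therefore estimated at 9 ug/mL in this assay, with a range from 4 ug/mL to 20 ug/mL. The expected step is an at least 1.1-fold lower number from compound 1 to compound 3 (0.04 log units; that floor lies within the scatter).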

Compound 3, half-maximal inhibitory concentration: > 10 ug/mL
Compound 3 ended at the assay's limit (the forecaster's own chance of this, stated with the estimate: 50%); at least 1.1-fold (0.04 log units) between middle value and limit.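

Going by these compounds alone, no step from compound 1 to compound 3 can be read in this assay, because both compounds end at a limit of the assay and not at a measured number: the limit of > 10 ug/mL in this assay, at which 2 of the 3 values shown sit. The compounds shown leave open whether the methyl of compound 3 changes the read-out at all, and by how much.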